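The source may report more compounds than this note shows. Statements on the series, on what has been measured and on what is new or still open speak of the compounds shown alone.

Three compounds share one core and differ only in the aryl group attached to the five-membered ring. Compound 1 `O=c1c2ccccc2[se]n1-c1nnc(-c2cccc([N+](=O)[O-])c2)s1` gives 16100 nM in a functional assay on A549 cells (Homo sapiens) for antiproliferative activity, read by CCK-8 assay, with a stated time of 48 h; on this read-out higher numbers stand for weaker inhibition and lower numbers for stronger inhibition. Compound 2 `O=c1c2ccccc2[se]n1-c1nnc(-c2ccc(Br)cc2)s1` gives 39100 nM in this assay, the highest of the three numbers and so the weakest inhibition seen here; compound 3 `COc1ccc(-c2nnc(-n3[se]c4ccccc4c3=O)s2)cc1` gives 5930 nM. Among the compounds with values here, the one step that can be followed between neighbours is a 6.6-fold lower number from compound 2 to compound 3 (0.82 log units; beyond the scatter). Compound 4 `Cc1cccc(-c2nnc(-n3[se]c4ccccc4c3=O)s2)c1` has not been measured; relative to compound 2 the change is 3-methylphenyl in place of 4-bromophenyl on an aromatic carbon. Within the data shown here, no measured step exchanges a bromo for a methyl, nor changes where the substituent sits on the phenyl ring, so the step from compound 2 to compound 3 only shows that replacing the bromo can lower the number noticeably. The expected outcome for compound 4 is a smaller move in the same direction, a 2.6-fold lower number from compound 2 to compound 4 (0.42 log units; beyond the scatter), with wide uncertainty. Compound 4 is therefore estimated at 15000 nM in this assay, within a range from 5000 nM to 45000 nM.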

Compound 4, half-maximal inhibitory concentration: 14800 nM
Compound 4: the middle estimate sits 1.0-fold (0.01 log units) above what was measured; low and high end bracket the measured number.
By their numbers in this assay, from the lowest: compound 3; then compounds 4 and 1 (each within the scatter of the next); then compound 2.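

In this assay, within the data shown here, 3-methylphenyl in place of 4-bromophenyl gives a 2.6-fold lower number from compound 2 to compound 4 (0.42 log units; beyond the scatter), so the methoxy group of compound 3 is not the only change at this position that lowers the number. Methyl in place of nitro gives a 1.1-fold lower number from compound 1 to compound 4 (0.04 log units; within the scatter), so these two quite different groups cannot be told apart on this read-out. Nothing shown here explains these numbers.

From the compounds shown here alone, the 3-methylphenyl for 4-bromophenyl change swaps the substituent and alters where it sits on the phenyl ring in a single step, so how much each of these contributes remains open. Going by these compounds, it also remains open how the number would respond to an amine, a carboxylic acid or a longer alkyl chain on that phenyl ring.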